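The compounds below may be only part of what the source reports. "The series", "measured", "known", "first", "only" and "open" are said of these compounds alone.

In an ADME assay (liver) for metabolic stability, with Liver microsome (Homo sapiens) as the target, read by LC-MS, using microsomes, with a stated time of 1 h, tested at 5 uM (a lower number here means that less of the compound is left, a higher number that more of the compound is left), compound 3 (`COc1cc(OC)cc(N2CCN(C(=O)c3oc(C)nc3-c3cccc(F)c3)CC2)c1`) gives 11.3%, which lies within the scatter of compound 2 (`COc1cc(OC)cc(N2CCN(C(=O)c3oc(C)nc3-c3ccccc3F)CC2)c1`) at 15%. Compound 1 (`Cc1ccc(C)c(N2CCN(C(=O)c3oc(C)nc3-c3ccccc3)CC2)c1`) reads 33.8%, a gap to compound 3 that is beyond the scatter.

The next structure is compound 4 (`COc1cc(OC)cc(N2CCN(C(=O)c3oc(C)nc3-c3ccccc3)CC2)c1`). The change is hydrogen in place of fluoro on an aromatic carbon, or 3-fluorophenyl to phenyl.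

Among the measured compounds shown here, one measured step bears on this directly: a number 3.7 percentage points lower from compound 2 to compound 3 (within the scatter), with 3-fluorophenyl in place of 2-fluorophenyl. It shows no change beyond the scatter, but it only relocates the fluoro. For the measured compounds named here, no measured pair removes the fluoro outright. Compound 1 also carries the phenyl, but it differs from compound 4 elsewhere, so it gives only weak support for a higher number.

No shift beyond the scatter is therefore expected, and the expected step is a number 2.7 percentage points higher from compound 3 to compound 4 (within the scatter). For compound 4 the estimate is 14%, with an expected range from 6% to 26%.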

Compound 4, percent of the compound remaining: 15.8%
Beside the measured number, compound 4's estimate is 1.8 percentage points below it, and the stated range covers the measured number.
By their numbers in this assay, from the lowest: compounds 3, 2 and 4 (each within the scatter of the next); then compound 1.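

In this assay, taking the fluoro off altogether gives a number 4.5 percentage points higher from compound 3 to compound 4 (within the scatter) and also a number 0.8 percentage points higher from compound 2 to compound 4 (within the scatter), so phenyl, 3-fluorophenyl and 2-fluorophenyl cannot be told apart in this series with the 3,5-dimethoxyphenyl group in place. Among the compounds shown here, with phenyl held constant, the other aryl group now has a clean comparison: a number 18 percentage points lower from compound 1 to compound 4 (beyond the scatter), the only step so far beyond the scatter, with 3,5-dimethoxyphenyl in place of 2,5-dimethylphenyl on an amine nitrogen in a ring. Nothing available gives a reason for either outcome.

From the compounds shown here alone, whether a nitrile, a methoxy or a carboxylic acid on the phenyl would also leave the number unmoved stays open. So does whether 2,5-dimethylphenyl keeps its higher number when the phenyl carries a fluoro.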